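The compounds below may be only part of what the source reports. "The series", "measured", "known", "first", "only" and "open" are said of these compounds alone.

The measured compounds and their values:

compound 1, `COc1ccc(N/N=C2\CCC(C)n3c2ncc(C(=O)O)c3=O)cc1` — in a functional assay on the whole organism for inhibition, with Rattus norvegicus as the target (a lower number here means that less compound is needed, a higher number that more compound is needed for the effect), compound 1 gives 7.6 umol/kg
compound 2, `Cc1ccccc1N/N=C1\CCC(C)n2c1ncc(C(=O)O)c2=O` — in this assay compound 2 gives only a limit, > 100 umol/kg

Compound 1 holds the only number shown in this assay; the other entry is a limit. Compound 2 sits at the limit of the limit of > 100 umol/kg in this assay, at which 1 of the 2 values shown sits, so the step of an at least 13-fold higher number from compound 1 to compound 2 (1.11 log units; beyond the scatter) is large and loses the effect within the tested range.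

Compound 3, `CC(=O)c1ccc(N/N=C2\CCC(C)n3c2ncc(C(=O)O)c3=O)cc1`, differs from compound 1 by acetyl in place of methoxy on an aromatic carbon. For the measured compounds named here, the one measured step, from compound 1 to compound 2, swaps the whole aryl substituent for a group at a different place, so it bears on the present change only loosely; it shows that the aryl substituent matters, not what a para acetyl does. Going by the values given here, no measured step speaks directly to acetyl against methoxy.

A modest step is therefore expected, more likely towards a higher number than a lower one, and the step of a 2.0-fold higher number from compound 1 to compound 3 (0.30 log units; within the scatter) is estimated accordingly. Compound 3 is expected to give about 15 umol/kg, with a range from 5 umol/kg to 60 umol/kg.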

Compound 3, dose for 50% inhibition: > 100 umol/kg
Compound 3: no number, only a limit; the forecaster's own chance of this, stated with the estimate: 15%; middle value at least 6.6-fold (0.82 log units) from the limit.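

Held at the same place, on an aromatic carbon para to a large group, the change from methoxy to acetyl gives an at least 13-fold higher number from compound 1 to compound 3 (1.11 log units; beyond the scatter) in this assay. The earlier step changed the aryl substituent and its place together, whereas this one shows that the effect within the tested range can be lost through the group at this single position, so having a group there does not by itself preserve the effect. For compound 3, > 100 umol/kg is a limit, and compound 1 remains the only compound with a number, while the other two sit at the same limit: the limit of > 100 umol/kg in this assay, at which 2 of the 3 values shown sit.

The compounds shown leave open whether the effect depends on methoxy itself or would also be kept by another group at this place, such as ethoxy, hydroxyl, an amine or chlorine, and how a ring with no group at this place would compare. They also leave open how far the number for compound 3 lies beyond the limit, so the full size of the step cannot be read.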